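Ethoxycarbonyl in place of cyano on a shared core

The source may hold more compounds than are shown below. What is called first, only, known or untested is meant among the compounds shown, and "the series" means these compounds.

In a physicochemical assay for metabolic stability, read by spectrophotometry, in phosphate buffer, at 25 degrees C, at pH 7.3 (on this read-out higher numbers stand for a longer-lived compound and lower numbers for a shorter-lived compound), compound 1 (`Cc1cccc(C(=O)n2cc(C#N)c3cccnc32)c1`) gives 1.9 h and compound 2 (`Cc1ccc(C(=O)n2cc(C#N)c3cccnc32)cc1`) gives 2.6 h and the two values lie within the scatter of each other. Going by the values given here, compound 1 therefore stands level with the only other number available.

Compound 3 (`CCOC(=O)c1cn(C(=O)c2cccc(C)c2)c2ncccc12`) has not yet been measured. It keeps the core of compound 1 but carries ethoxycarbonyl in place of cyano on an aromatic carbon of the five-membered aromatic ring. Among the compounds with values here, no measured pair shows a change at this place, so the expectation rests on the structural change alone and remains loose.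

Starting from compound 1 at 1.9 h in this assay a modest step towards a longer-lived compound is expected, only a little beyond the scatter. The estimated step is a 2.4-fold higher number from compound 1 to compound 3 (0.37 log units; beyond the scatter) on this expectation. For compound 3 the estimated half-life is 4.5 h with an expected range from 2 h to 10 h when the measurement is made.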

Compound 3, half-life: 3.5 h
Beside the measured number, compound 3's estimate is 1.3-fold (0.11 log units) above it; low and high end bracket the measured number.
By their numbers in this assay, from the lowest: compounds 1, 2 and 3 (each within the scatter of the next).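

The swap of cyano for ethoxycarbonyl on an aromatic carbon of the five-membered aromatic ring is the first change at this place among the compounds shown, and in this assay it amounts to a 1.8-fold higher number from compound 1 to compound 3 (0.27 log units; within the scatter). The half-life read-out therefore cannot tell compound 1 and compound 3 apart, even though the entering group is a larger chain than the cyano it replaces and brings an ester carbonyl where there had been a nitrile, so at this place the exchange leaves the number inside the usual spread of repeated measurements. Nothing measured here speaks to why the two compounds read alike.

As far as these compounds go, what remains open is whether any group at this place can move the half-life beyond the scatter, for instance a carboxylic acid, a primary amide or a longer chain such as butoxycarbonyl. From the compounds shown here alone, it is also open whether the same exchange would read the same way on the core of compound 2, since this single pair rests on the core of compound 1 alone.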